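Azaindole for benzimidazole on the amide-linked methylene

The compounds below may be only part of what the source reports. "The series", "measured", "known", "first", "only" and "open" are said of these compounds alone.

Measured compounds:
- compound 1, `CCOc1ncc(-c2nc(C(F)(F)F)sc2N2CCN(C(=O)Cn3cnc4cccnc43)[C@H](C)C2)cn1`, in a functional assay on U2OS cells for antagonist activity at C-X-C chemokine receptor type 3 (Homo sapiens), read by beta-arrestin recruitment (a lower number here means a stronger inhibitor, a higher number a weaker inhibitor), compound 1 gives 20 nM
- compound 2, `COCCOc1ncc(-c2nc(C(F)(F)F)sc2N2CCN(C(=O)Cn3cnc4cccnc43)[C@H](C)C2)cn1`, in this assay compound 2 gives 324 nM
- compound 3, `CCOc1ncc(-c2nc(C(F)(F)F)sc2N2CCN(C(=O)Cn3cnc4ccccc43)[C@H](C)C2)cn1`, in this assay compound 3 gives 49 nM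

Compound 3 has the second highest of the three numbers. Compound 1 stands nearest, and that pair is a measured step: a 2.5-fold higher number from compound 1 to compound 3 (0.39 log units; beyond the scatter). Within the data shown here, compound 2 sits furthest away, with the highest number of the set; no single-point step links it to compound 3.

Compound 4, `CCOc1ncc(-c2nc(C(F)(F)F)sc2N2CCN(C(=O)Cn3ccc4cccnc43)[C@H](C)C2)cn1`, has the same atoms as compound 3, joined differently: a group of 9 heavy atoms (7 carbon, 2 nitrogen; one five-membered aromatic ring with 1 hetero atom, one six-membered aromatic ring with 1 hetero atom) in place of a group of 9 heavy atoms (7 carbon, 2 nitrogen; one five-membered aromatic ring with 2 hetero atoms, one six-membered aromatic ring of carbon only), on a saturated chain carbon bound to a carbonyl carbon.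

Among the measured compounds shown here, only one measured step bears on this position, the exchange of bicyclic groups on the carbon bound to the carbonyl: a 2.5-fold higher number from compound 1 to compound 3 (0.39 log units; beyond the scatter), a modest shift. The step from compound 1 to compound 2 concerns the other end of the molecule and says nothing about this change. Compound 4 keeps one nitrogen in each ring, so the step from compound 3 is expected to be small, at most modest, with a slight lean toward a lower number: a 1.3-fold lower number from compound 3 to compound 4 (0.11 log units; within the scatter) is the expected step.

Compound 4 is therefore estimated at 38 nM in this assay, with an expected range from 14 nM to 105 nM.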

Compound 4, half-maximal inhibitory concentration: 47 nM
The estimate for compound 4 lay 1.2-fold (0.09 log units) below the measured number; the range from low to high includes it.
By their numbers in this assay, from the lowest: compound 1; then compounds 4 and 3 (each within the scatter of the next); then compound 2.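

In this assay, exchanging 1H-benzimidazol-1-yl for the group with one hetero atom in each ring gives a 1.0-fold lower number from compound 3 to compound 4 (0.02 log units; within the scatter), so moving a nitrogen from the five-membered ring to the six-membered ring leaves the number within the scatter for this pair. Among these compounds, the group on compound 1, with its third nitrogen, is the one that stands apart: replacing it gives a 2.4-fold higher number from compound 1 to compound 4 (0.37 log units; beyond the scatter) with the group of compound 4 and a 2.5-fold higher number from compound 1 to compound 3 (0.39 log units; beyond the scatter) with 1H-benzimidazol-1-yl, both beyond the scatter, which the single earlier step could not show. No measurement available here accounts for these steps.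

These compounds do not settle whether the lower number of compound 1 comes from the nitrogen count or from the particular arrangement of the nitrogens, since no other group with that count is available for comparison. Going by these compounds, it also remains open whether a bicyclic group is needed at all on the saturated chain carbon bound to the carbonyl carbon, or whether a simple phenyl ring or a dimethylamino group would serve there, and whether any of these exchanges would read the same with the methoxyethoxy chain of compound 2.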